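The compounds below may be only part of what the source reports. "The series", "measured", "known", "first", "only" and "open" are said of these compounds alone.

Three small molecules built on one shared core have been tested in a functional assay for antagonist activity at Neuropeptides B/W receptor type 1 (Homo sapiens), read by cAMP accumulation; on this read-out higher numbers stand for weaker inhibition and lower numbers for stronger inhibition. Compound 1, `Cc1ccc(-c2nc3cc([N+](=O)[O-])ccc3[nH]2)cc1C`, gives 1380 nM in this assay. Compound 2, `Cc1cc(-c2nc3cc([N+](=O)[O-])ccc3[nH]2)ccc1Cl`, differs from compound 1 in one place: chloro in place of methyl on an aromatic carbon. That change gave a 1.7-fold higher number from compound 1 to compound 2 (0.22 log units; within the scatter). Compound 3, `Cc1ccc(-c2nc3cc([N+](=O)[O-])ccc3[nH]2)c(C)c1`, is made of the same atoms as compound 1, joined differently; the difference between the two cores is not broken down here. In this assay compound 3 gives 1540 nM, and compound 2 gives 2290 nM. All three numbers lie within the usual scatter of one another, so none of them can be called stronger or weaker than another.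

Compound 4, `Cc1cc(Cl)ccc1-c1nc2cc([N+](=O)[O-])ccc2[nH]1`, has not yet been measured. It differs from compound 3 by chloro in place of methyl on an aromatic carbon. Within the data shown here, this is the same kind of change as the one from compound 1 to compound 2, but not the same change: in compound 2 the chloro sits ortho to a methyl group, whereas in compound 4 it sits meta to a methyl group, in both cases para to a large group. Because the same kind of change once gave a 1.7-fold higher number from compound 1 to compound 2 (0.22 log units; within the scatter), a step of similar size is expected here, namely a 1.5-fold higher number from compound 3 to compound 4 (0.17 log units; within the scatter). On that basis compound 4 is estimated at 2300 nM, with a likely range from 1200 nM to 4600 nM.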

Compound 4, half-maximal inhibitory concentration: 2490 nM
Compound 4: middle estimate off by 1.1-fold (0.03 log units), on the low side; the measured number falls inside the stated range.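

Putting chloro in place of methyl on an aromatic carbon gave a 1.6-fold higher number from compound 3 to compound 4 (0.21 log units; within the scatter) in this assay. Set beside the earlier case, the change behaves alike on both cores, with steps that cannot be told apart: the same change on two cores in this assay, a 1.7-fold higher number (0.22 log units; within the scatter) from compound 1 to compound 2 and a 1.6-fold higher number (0.21 log units; within the scatter) from compound 3 to compound 4, 1.0-fold (0.01 log units) apart, within the scatter of two such steps. This shows that, in these two pairs, the swap carries from one core to the other without any sign of a different outcome, but each step lies within the usual scatter of repeated measurements, so neither pair shows that chloro and methyl truly differ here, and two pairs say nothing about how the swap would behave on other cores.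

Still open, on these data alone, is whether a quite different group in this place, such as an amine, a carboxylic acid or a longer chain like propyl, would shift the number beyond the scatter, which the close agreement of chloro and methyl cannot predict. As far as these compounds go, all four compounds also carry the same nitro group on the shared core, so how the numbers would respond if a nitrile or an amide stood there instead also remains open.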